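A few compounds are considered here, and "the series" means these few. Any claim that something is new, unique, unknown or untested is made for them only; others in the source may bear on it.

Measured compounds in an assay on membranes from HeLa cells for displacement of a labelled ligand from adenosine receptor A3 (Homo sapiens), read by scintillation counting, with a stated time of 180 min, tested at 1 uM; on this read-out higher numbers stand for more inhibition at the one concentration tested (going by the name of the read-out) and lower numbers for less inhibition:
compound 1 `COC(=O)C1=C(C)NC(=O)NC1c1ccoc1`: 2%
compound 2 `COC(=O)C1=C(C)NC(=O)NC1c1cccs1`: 3%

Going by the values given here, compound 2 has the higher of the two numbers in this assay, but its only neighbour, compound 1, lies a number 1 percentage points higher from compound 1 to compound 2 (within the scatter), so the two values are indistinguishable. Compound 3 `CC1=C(C(=O)OCC(C)C)C(c2cccs2)NC(=O)N1` carries a different change: isopropyl in place of hydrogen on a saturated chain carbon bound to an oxygen next to a carbonyl group. Among the compounds with values here, no measured step touches this part of the molecule; the one step known swaps the ring on the saturated ring carbon instead. With nothing to guide the direction, compound 3 is expected to stay near compound 2, a step of a number 2 percentage points higher from compound 2 to compound 3 (within the scatter) that is not expected to exceed the scatter. Compound 3 is estimated at 5%, ranging from 0% to 20%.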

Compound 3, a percentage reported as inhibition, at one concentration (the size of the read-out at that concentration, not a potency): 11%
Estimate against measurement, compound 3: 6 percentage points below, and the stated range covers the measured number.
By their numbers in this assay, from the lowest: compounds 1, 2 and 3 (each within the scatter of the next).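

Going from methoxy to isobutoxy is the first change shown at this end of the molecule, and in this assay it gives a number 8 percentage points higher from compound 2 to compound 3 (within the scatter), so this change cannot be told apart from repeat variation. The same holds for the ring swap shown earlier. No measured evidence bears on this reading.

Going by these compounds, whether a carboxylic acid, an amide or a longer chain such as octyloxy here would move the number stays open. So does whether isobutoxy would read the same with furan-3-yl on the saturated ring carbon.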